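Cyano to carbamoyl on the aryl triazole oxime ether

The source may hold more compounds than are shown below. What is called first, only, known or untested is meant among the compounds shown, and "the series" means these compounds.

- compound 1 `COc1ccc([C@@H]2C/C(=N/OCc3cn(-c4ccc(C#N)cc4)nn3)c3cc(CC=C(C)C)c(OC)cc3O2)cc1`: 50%
- compound 2 `COc1ccc([C@@H]2C/C(=N/O)c3cc(CC=C(C)C)c(OC)cc3O2)cc1`: 47%
- compound 3 `C#CCOc1ccc([C@@H]2CC(=O)c3cc(CC=C(C)C)c(OC)cc3O2)cc1`: 75%

All three values come from a functional assay on HCT-116 cells (Homo sapiens) for inhibition, read by sulforhodamine B assay, with a stated time of 48 h, tested at 50 uM; on this read-out lower numbers stand for less inhibition of growth and higher numbers for more inhibition of growth at the one concentration tested. Compound 1 lies within the scatter of compound 2, and their values show no separation. Compound 3 reads higher than compound 1, and that gap lies beyond the scatter.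

The next compound to test is compound 4 `COc1ccc([C@@H]2C/C(=N/OCc3cn(-c4ccc(C(N)=O)cc4)nn3)c3cc(CC=C(C)C)c(OC)cc3O2)cc1`. Its difference from compound 1 is carbamoyl in place of cyano on an aromatic carbon, para to a large group. The rest of the structure is unchanged.

Among the compounds with values here, no measured pair in this small series covers this change, so the data give no direct precedent for it. In this assay, no step beyond the scatter is expected, and no direction is strongly favoured. The expected a number 4 percentage points lower from compound 1 to compound 4 (within the scatter) is therefore small. For compound 4 the estimated value is 46%, with an expected range from 30% to 62%.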

Compound 4, percent growth inhibition at one concentration: 100%
The estimate for compound 4 lay 54 percentage points below the measured number; measured number above the stated range.
By their numbers in this assay, from the lowest: compounds 2 and 1 (each within the scatter of the next); then compound 3; then compound 4.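

In this assay, replacing cyano with carbamoyl on an aromatic carbon, para to a large group, gives a number 50 percentage points higher from compound 1 to compound 4 (beyond the scatter). Within the data shown here, the earlier compounds offered no change at this place, so this is the first sign that the read-out is sensitive to the group held there, with a swap from cyano (0 hydrogen-bond donors) to carbamoyl (1 hydrogen-bond donor) being enough to move it well beyond the scatter. Nothing measured here accounts for the step.

From the compounds shown here alone, it remains open whether a carboxylic acid, a methyl ester or a dimethylcarbamoyl group at this place would read like carbamoyl or like cyano. With compound 4 at 100% at a single concentration, how much further the carbamoyl compound stands from compound 1 at lower concentrations also stays unresolved.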